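Arginine amide replacement of aminopropyl in cytotoxic bis-benzyl amides

The source may report more compounds than this note shows. Statements on the series, on what has been measured and on what is new or still open speak of the compounds shown alone.

Compound 1 `NCCCNC(=O)C(CN)(Cc1ccc(C(F)(F)F)cc1)Cc1ccc(C(F)(F)F)cc1`: 11000 nM
Compound 2 `NCCCNC(=O)C(CN)(Cc1ccc2ccccc2c1)Cc1ccc2ccccc2c1`: 4300 nM
Compound 3 `N=C(N)NCCC[C@H](NC(=O)C(CN)(Cc1ccc(C(F)(F)F)cc1)Cc1ccc(C(F)(F)F)cc1)C(N)=O`: > 254000 nM

Compound 1 and compound 2 share the same chain on the amide-type nitrogen; the difference between their two cores is not broken down here. In a functional assay on Ramos cells (Homo sapiens) for cytotoxicity, read by MTT assay, with a stated time of 4 h (a higher number here means a weaker inhibitor, a lower number a stronger inhibitor), compound 1 gives 11000 nM, and compound 2 gives 4300 nM, the lower of the two numbers. For compound 3 the assay reports only a limit, > 254000 nM. The change from compound 1 to compound 3 is a group of 11 heavy atoms (6 carbon, 4 nitrogen, 1 oxygen; no ring) in place of a group of 4 heavy atoms (3 carbon, 1 nitrogen; no ring), on an amide-type nitrogen, and it made an at least 23-fold higher number from compound 1 to compound 3 (1.36 log units; beyond the scatter), resting on (the limit of > 254000 nM in this assay, at which 1 of the 3 values shown sits).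

Compound 4 `N=C(N)NCCC[C@H](NC(=O)C(CN)(Cc1ccc2ccccc2c1)Cc1ccc2ccccc2c1)C(N)=O` has not yet been measured. It differs from compound 2 by a group of 11 heavy atoms (6 carbon, 4 nitrogen, 1 oxygen; no ring) in place of a group of 4 heavy atoms (3 carbon, 1 nitrogen; no ring), on an amide-type nitrogen, the same change as that from compound 1 to compound 3. Because the earlier step was an at least 23-fold higher number from compound 1 to compound 3 (1.36 log units; beyond the scatter), a comparably large weakening is expected, a 35-fold higher number from compound 2 to compound 4 (1.54 log units; beyond the scatter), starting from the number of compound 2, 4300 nM. Compound 4 is therefore estimated at 150000 nM, expected between 40000 nM and 500000 nM, with a real chance that only a limit is reported.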

Compound 4, half-maximal inhibitory concentration: 107000 nM
Estimate against measurement, compound 4: 1.4-fold (0.15 log units) above; low and high end bracket the measured number.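

On the second core the change again gives a large rise in this assay, with a 25-fold higher number from compound 2 to compound 4 (1.40 log units; beyond the scatter), so the effect seen on the core of compound 1 recurs on the core of compound 2. The two steps can be compared only this far: the same change on two cores in this assay, an at least 23-fold higher number (1.36 log units; beyond the scatter) from compound 1 to compound 3 and a 25-fold higher number (1.40 log units; beyond the scatter) from compound 2 to compound 4; the limit leaves it open whether they differ Compound 3 is reported only as a limit, and two cores alone set no rule for other cores in this series: the limit of > 254000 nM in this assay, at which 1 of the 4 values shown sits.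

The compounds shown leave open whether a longer amine chain on the amide-type nitrogen would behave in the same way. They also leave open what a chain bearing a carboxylic acid in place of the carboxamide would do on either core.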